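The compounds below may be only part of what the source reports. "The series", "measured", "known", "first", "only" and "open" are said of these compounds alone.

Compounds 1, 2 and 3 share one core and differ only in the amide group on the carbonyl carbon. Compound 1 `COc1ccc(OC)c(-c2cc(-c3ccc(C(=O)N(C)C)s3)on2)c1` carries a dimethylamino group there; in a functional assay on PC-3 cells (Homo sapiens) for cytotoxicity, read by XTT assay, with a stated time of 72 h (on this read-out lower numbers stand for stronger inhibition and higher numbers for weaker inhibition), compound 1 gives > 30000 nM, which is a limit of the assay rather than a number. Compound 2 `COc1ccc(OC)c(-c2cc(-c3ccc(C(=O)N4CCCCC4)s3)on2)c1` carries a piperidin-1-yl group. In this assay compound 2 gives > 30000 nM, again a limit. Compound 3 `CCCN(C)C(=O)c1ccc(-c2cc(-c3cc(OC)ccc3OC)no2)s1` carries a methyl(propyl)amino group. In this assay compound 3 gives > 30000 nM, also a limit, so compound 3 stands exactly where its two companions stand, at the limit of > 30000 nM in this assay, at which 3 of the 3 values shown sit. The steps between them, a step that the two limits leave unreadable from compound 1 to compound 2, a step that the two limits leave unreadable from compound 1 to compound 3 and a step that the two limits leave unreadable from compound 2 to compound 3, cannot be sized; both ends of each sit at a limit. Compound 4 `CCN(CC)C(=O)c1ccc(-c2cc(-c3cc(OC)ccc3OC)no2)s1` differs from compound 3 by diethylamino in place of methyl(propyl)amino on a carbonyl carbon. Within the data shown here, no measured step speaks directly to this change, and the three unreadable steps show only that varying the amide group has not moved any compound off the limit. Compound 4 is therefore expected to sit at or near the limit as well, with an expected step that the limit leaves unreadable from compound 3 to compound 4. Compound 4 is estimated at 45000 nM, in a range from 15000 nM to 150000 nM.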

Compound 4, half-maximal inhibitory concentration: > 30000 nM
Compound 4: a limit, no number; the forecaster's own chance of this, stated with the estimate: 85%; the middle value lies beyond the limit too.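

Compound 4 also gives a limit rather than a number, so its steps from compound 1, compound 2 and compound 3 cannot be read: the limit of > 30000 nM in this assay, at which 4 of the 4 values shown sit. As far as these compounds go, whether any amide group on the shared core would give an actual number in this assay stays open.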